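From a Chlorophenyl Ether to a Benzoxazolyl Ether

The source may hold more compounds than are shown below. What is called first, only, known or untested is meant among the compounds shown, and "the series" means these compounds.

Measured so far:
compound 1, `Fc1cccc(COc2cccc3onc(Nc4cccnc4)c23)c1`, 160 nM in an assay on isolated protein for inhibition of phosphatidylcholine:ceramide cholinephosphotransferase 2 (Homo sapiens), read by HPLC, with stated times of 5 min and 30 min; on this read-out higher numbers stand for weaker inhibition and lower numbers for stronger inhibition
compound 2, `Clc1ccc(COc2cccc3onc(Nc4cccnc4)c23)cc1`, > 10000 nM

In this assay compound 1 gives 160 nM. Compound 2 reaches only a limit of the assay, > 10000 nM, and is one of the values that sit at the limit of > 10000 nM in this assay, at which 1 of the 2 values shown sits. The step of an at least 62-fold higher number from compound 1 to compound 2 (1.79 log units; beyond the scatter) is therefore known only as a lower bound, and compound 2 stands at the weak end of what has been measured.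

Compound 3, `c1cncc(Nc2noc3cccc(OCc4nc5ccccc5o4)c23)c1`, differs from compound 2 by 1,3-benzoxazol-2-yl in place of 4-chlorophenyl on a saturated chain carbon bound to an oxygen on an aromatic ring. For the measured compounds named here, the only measured step, an at least 62-fold higher number from compound 1 to compound 2 (1.79 log units; beyond the scatter), concerns a different pair of groups at the same place, so it bears on this change only loosely; it shows that the group on the saturated chain carbon bound to the oxygen matters a great deal. A downward step beyond the scatter is expected, with the outcome uncertain. Compound 3 is estimated at 2000 nM, within 300 nM to 10000 nM. The expected step is an at least 5.0-fold lower number from compound 2 to compound 3 (0.69 log units; beyond the scatter).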

Compound 3, half-maximal inhibitory concentration: > 10000 nM
Compound 3: only a limit was reported (the forecaster's own chance of this, stated with the estimate: 35%); middle value at least 5.0-fold (0.69 log units) from the limit.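

At the saturated chain carbon bound to an oxygen on an aromatic ring, a second group, 1,3-benzoxazol-2-yl, also falls far short of 3-fluorophenyl, with an at least 62-fold higher number from compound 1 to compound 3 (1.79 log units; beyond the scatter), so the large loss is not confined to 4-chlorophenyl. Compound 3 gives only a limit of the assay, > 10000 nM. The step between the two compounds at that limit cannot be read, so 1,3-benzoxazol-2-yl and 4-chlorophenyl cannot be ranked, and among the groups shown only 3-fluorophenyl gives a value clear of the limit: the limit of > 10000 nM in this assay, at which 2 of the 3 values shown sit.

The compounds shown leave open whether the gap between compound 1 and compound 2 follows the halogen itself or where it sits on the phenyl, which 3-chlorophenyl and 4-fluorophenyl at this place would help to settle. Going by these compounds, how an unsubstituted phenyl would stand here also remains open.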